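Trading oxan-4-yl for 3,5-difluorophenyl on compound 2

The source may hold more compounds than are shown below. What is called first, only, known or untested is meant among the compounds shown, and "the series" means these compounds.

In an ADME assay on MRC5 cells (Homo sapiens) for inhibition, with a stated time of 72 h (a higher number here means that more compound is needed for the effect, a lower number that less compound is needed), compound 1 `CO[C@H]1CC[C@H](NC(=O)c2n[nH]cc2NC(=O)c2ccc(F)cc2F)CC1` gives 11000 nM. Compound 2 `CO[C@H]1CC[C@H](NC(=O)c2n[nH]cc2NC(=O)C2CCOCC2)CC1` gives > 50000 nM, which is a limit of the assay and not a number. The next structure is compound 3 `CO[C@H]1CC[C@H](NC(=O)c2n[nH]cc2NC(=O)c2cc(F)cc(F)c2)CC1`, and its change from compound 2 is this: 3,5-difluorophenyl in place of oxan-4-yl on a carbonyl carbon. In words, 3,5-difluorophenyl takes the place of oxan-4-yl on a carbonyl carbon. Among the compounds with values here, the one measured step that bears on this is an at least 4.5-fold higher number from compound 1 to compound 2 (0.65 log units; beyond the scatter), where oxan-4-yl replaced 2,4-difluorophenyl, and it lies beyond the scatter. Compound 3 runs that exchange in reverse, though with 3,5-difluorophenyl rather than the 2,4-difluorophenyl of compound 1 at 11000 nM, so a lower number of similar size is expected in this assay. The expected change is an at least 3.3-fold lower number from compound 2 to compound 3 (0.52 log units; beyond the scatter). For compound 3 the estimated value is 15000 nM, with an expected range of 5000 nM to 45000 nM.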

Compound 3, half-maximal effective concentration: 600 nM
Compound 3: the middle estimate sits 25-fold (1.40 log units) above what was measured, outside the stated range (below it).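

In this assay, the step of an at least 83-fold lower number from compound 2 to compound 3 (1.92 log units; beyond the scatter) shows that the phenyl ring on this carbonyl carbon can do far more than the earlier pair suggested. The step of an 18-fold lower number from compound 1 to compound 3 (1.26 log units; beyond the scatter) adds what the earlier pair could not show: both compounds of this step carry a difluorophenyl group, so the placing of the two fluorines on the ring matters here, and not merely the presence of a fluorinated phenyl ring. The true size of the first step stays unknown because compound 2 gives only a limit of the assay and not a number: the limit of > 50000 nM in this assay, at which 1 of the 3 values shown sits.

On these data alone, it remains open how a plain phenyl group or a 3,5-dichlorophenyl group would compare with 3,5-difluorophenyl on this carbonyl carbon. The compounds shown also cannot say why moving the fluorines changes the number so much.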